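Replacing the sulfonyl group on the amine nitrogen with butoxycarbonyl

The compounds below may be only part of what the source reports. "The series", "measured", "known", "first", "only" and "open" are said of these compounds alone.

Measured so far in a functional assay (plasma) for inhibition, with Homo sapiens as the target; on this read-out higher numbers stand for weaker inhibition and lower numbers for stronger inhibition:
- compound 1 `Cc1ccc(S(=O)(=O)N[C@@H](CNC(=O)c2ccc3oc(-c4ccc(C(=N)N)cc4)nc3c2)C(=O)O)cc1`: 10 nM
- compound 2 `CCCCOC(=O)N[C@@H](CNC(=O)c1ccc2nc(-c3ccc(C(=N)N)cc3)oc2c1)C(=O)O`: 20 nM

Only these two numbers exist for the series, and they lie within the scatter of each other, so compound 1 cannot be ranked against compound 2. Both sit in the low nanomolar range.

The next compound to be measured is compound 3 `CCCCOC(=O)N[C@@H](CNC(=O)c1ccc2oc(-c3ccc(C(=N)N)cc3)nc2c1)C(=O)O`, which has butoxycarbonyl in place of (4-methylphenyl)sulfonyl on an amine nitrogen. The core of compound 1 is kept.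

Among the measured compounds shown here, no measured pair isolates this change, so the data give no direct size for it. The nearest guide is compound 2, which also carries butoxycarbonyl on an amine nitrogen and gives 20 nM. On that basis no change beyond the scatter is expected in this assay, with any drift towards a higher number. The expected step is a 1.5-fold higher number from compound 1 to compound 3 (0.18 log units; within the scatter). For compound 3 the estimated value is 15 nM, with an expected range from 6 nM to 40 nM.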

Compound 3, half-maximal inhibitory concentration: 20 nM
Beside the measured number, compound 3's estimate is 1.3-fold (0.12 log units) below it; low and high end bracket the measured number.
By their numbers in this assay, from the lowest: compounds 1, 2 and 3 (each within the scatter of the next).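

In this assay, among the compounds shown here, putting butoxycarbonyl in place of (4-methylphenyl)sulfonyl on the amine nitrogen gives a 2.0-fold higher number from compound 1 to compound 3 (0.30 log units; within the scatter), the first direct reading of this exchange on the core of compound 1. The entering group has no ring and fewer heavy atoms than the leaving group, so on this core neither the six-membered aromatic ring nor the sulfur is needed for a value in the low nanomolar range. This rests on a single pair, which supports no trend beyond compound 1 and compound 3.

On these data alone, it remains open how much else this nitrogen accepts, for example a free amine, an acetyl group, a longer chain than butoxycarbonyl, or a phenylsulfonyl group with a fluorine atom in place of the methyl. As far as these compounds go, it is also open whether the two groups would stay within the scatter of each other on another core or in another read-out.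

Nothing in the available evidence accounts for the size of this step.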